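A few compounds are considered here, and "the series" means these few. Any claim that something is new, unique, unknown or untested is made for them only; others in the source may bear on it.

Compound 1 `O=C(O)c1cc(-c2cccc(COc3ccc4c(c3)CN(C3CCC3)C4=O)c2)ccc1Cl` is the higher of the two compounds measured in an assay on HEK293 cells for positive allosteric modulation of metabotropic glutamate receptor 2 (Rattus norvegicus), read by thallium flux; a lower number here means a smaller maximal response, a higher number a larger maximal response: compound 1 gives 90.3%. Compound 2 `O=C(O)c1cc(-c2cccc(COc3ccc4c(c3)CCN(C3CCCC3)C4=O)c2)ccc1Cl` gives 66.9% in this assay, a number that lies lower than that of compound 1 by more than the scatter of repeated measurements. Among the measured compounds shown here, no two measured compounds differ in a single place, so the data contain no isolated step that shows what one change alone does to the maximal response.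

Compound 3 `O=C(O)c1cc(-c2cccc(COc3ccc4c(c3)CN(C3CCCCC3)C4=O)c2)ccc1Cl` differs from compound 1 in one place: cyclohexyl in place of cyclobutyl on an amide-type nitrogen in a ring. The measured pair gives no direct guide to a change of this kind, so the expectation for compound 3 stays close to compound 1, with a modest downward lean that follows the lower value of compound 2 66.9%. Compound 3 is therefore expected to reach 80% in this assay, with a range from 60% to 100%, which amounts to an expected step of a number 10.3 percentage points lower from compound 1 to compound 3 (beyond the scatter).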

Compound 3, largest response reached (Emax), in percent of the reference or control that the assay uses: 63.3%
Estimate against measurement, compound 3: 16.7 percentage points above; the measured number falls inside the stated range.
By their numbers in this assay, from the lowest: compounds 3 and 2 (each within the scatter of the next); then compound 1.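

Among the compounds shown here, this is the first step that isolates a single change. On the amide-type nitrogen of the five-membered non-aromatic ring, cyclohexyl in place of cyclobutyl alters the maximal response in this assay and gives a number 27 percentage points lower from compound 1 to compound 3 (beyond the scatter) as the result. With the rest of the core unchanged, the group on this nitrogen is therefore shown to matter for the response, and the smaller of these two carbon-only rings gives the higher number. Nothing measured here explains this drop.

For the compounds shown here, with only two ring sizes to read on this core, the shape of the trend between them and beyond them stays open. On these data alone, it is also open whether an open chain such as isopropyl, or an oxygen-containing ring such as tetrahydropyranyl, on this nitrogen would hold the response of compound 1.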